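The compounds below may be only part of what the source reports. "The series", "measured", "known", "first", "only" and "open" are said of these compounds alone.

Measured so far in a functional assay on CHO cells with adenosine receptor A1 (Homo sapiens) as the target, read by cAMP accumulation and immunoassay, with a stated time of 6 min, tested at 0.1 uM; on this read-out lower numbers stand for a stronger effect and higher numbers for a weaker effect at the one concentration tested:
Compound 1, `Nc1scc(CN2CCN(c3ccncc3)CC2)c1C(=O)c1ccc(Cl)cc1`, gives 1.4%.
Compound 2, `Nc1scc(CN2CCC(c3ccc(Cl)cc3)CC2)c1C(=O)c1ccc(Cl)cc1`, gives -2.3%.
Compound 3, `Nc1scc(CN2CCN(c3cccc(F)c3)CC2)c1C(=O)c1cccc(C(F)(F)F)c1`, gives -12%.

Compound 1 stands highest of these three numbers. Compound 2 lies within the usual scatter of it, so the two cannot be told apart; compound 3 lies beyond the scatter, lower than compound 1. All three numbers sit close to zero, so on this read-out none of the three shows a marked effect at the one concentration tested.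

Compound 4, `Nc1scc(CN2CCN(CCCc3ccc(Cl)cc3)CC2)c1C(=O)c1ccc(Cl)cc1`, has not been measured yet. It differs from compound 1 in one place: 3-(4-chlorophenyl)propyl in place of pyridin-4-yl on an amine nitrogen in a ring. Among the measured compounds shown here, no step between measured compounds matches this change, so the expectation rests on the values alone. Compound 2, which carries a 4-chlorophenyl group in a comparable part of the molecule, gave -2.3%, a number within the scatter of compound 1. The step from compound 1 to compound 4 is therefore expected to be a number 4.4 percentage points lower from compound 1 to compound 4 (within the scatter), that is, no change beyond the scatter. Compound 4 is estimated to give -3%, within a range from -18% to 12%.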

Compound 4, a percentage reported as activity, at one concentration (the size of the read-out at that concentration, not a potency): -3%
Estimate against measurement, compound 4: no gap at the digits printed; low and high end bracket the measured number.
By their numbers in this assay, from the lowest: compounds 3, 4, 2 and 1 (each within the scatter of the next, the first and the last beyond it).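

In this assay, putting 3-(4-chlorophenyl)propyl in place of pyridin-4-yl on the amine nitrogen in the ring gives a number 4.4 percentage points lower from compound 1 to compound 4 (within the scatter) and so leaves the two compounds indistinguishable. Among the compounds shown here, this position therefore accepts a larger group, with a propyl chain and a carbon-only aromatic ring, even though the hydrogen-bond acceptor of pyridin-4-yl is lost, and the earlier compounds offered no such one-place comparison. No measurement shown gives a reason for this outcome.

Still open, as far as these compounds go, is whether a shorter or longer chain, or a chain ending in an amine or a carboxylic acid, would shift the number beyond the scatter. A reading at one concentration is not a potency, so compound 1 and compound 4 might still differ at other concentrations.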